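Chloro on the phenoxy ring: a small step from compound 1

The compounds below may be only part of what the source reports. "The series", "measured", "known", "first", "only" and "open" are said of these compounds alone.

Compound 1 `NC(=S)N/N=C(\COc1ccccc1)c1ccc(Br)cc1`: 54900 nM
Compound 2 `COc1cccc(OC/C(=N\NC(N)=S)c2ccc(Br)cc2)c1`: 50700 nM

In an ADME assay on L929 cells (Mus musculus) for cytotoxicity, read by resazurin assay, with a stated time of 96 h (a higher number here means that more compound is tolerated, a lower number that less compound is tolerated), compound 1 gives the highest of the two numbers, but compound 2 sits within the scatter of it; the step of a 1.1-fold lower number from compound 1 to compound 2 (0.03 log units; within the scatter) shows how little the methoxy changed. Compound 3 `NC(=S)N/N=C(\COc1ccc(Cl)cc1)c1ccc(Br)cc1` carries the difference (chloro in place of hydrogen on an aromatic carbon). Going by the values given here, only that one measured step bears on it, and it lay within the scatter, so no step beyond the scatter is expected in this assay. For compound 3 the estimate is 50000 nM, in the range 25000 nM to 100000 nM, which would mean an expected step of a 1.1-fold lower number from compound 1 to compound 3 (0.04 log units; within the scatter).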

Compound 3, half-maximal cytotoxic concentration: < 25100 nM
Compound 3: a limit, no number; the forecaster's own chance of this, stated with the estimate: 10%; middle value at least 1.9-fold (0.29 log units) away from the limit.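

In this assay, the change from phenyl to 4-chlorophenyl gives an at least 2.1-fold lower number from compound 1 to compound 3 (0.33 log units; beyond the scatter). This shows that a single substituent on this ring, para to a large group, can move the number beyond the scatter, which the methoxy of compound 2 did not do. The figure for compound 3 is a limit and not a number: the limit of < 25100 nM in this assay, at which 1 of the 3 values shown sits.

As far as these compounds go, how far the number of compound 3 actually lies from that of compound 1 stays open. So does whether fluoro, methyl or an amine at this place would give a step of similar size.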